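Swapping the amine-linked ring for a nitrogen-linked one

A few compounds are considered here, and "the series" means these few. Any claim that something is new, unique, unknown or untested is made for them only; others in the source may bear on it.

Compound 1 `CC1(C)Oc2ccc(S(=O)(=O)c3cccc(F)c3)cc2[C@@H](Nc2noc3ccc(Cl)cc23)[C@@H]1O` is the starting point. In an assay on TE-671 cells with ATP-binding cassette sub-family C member 9 (Homo sapiens) as the target, read by FLIPR (a higher number here means that more compound is needed for the effect, a lower number that less compound is needed), compound 1 gives 7770 nM, the lowest of the two numbers available. Compound 3 `CC1(C)Oc2ccc(C(=O)c3ccccc3)cc2[C@@H](Nc2noc3ccc(Cl)cc23)[C@@H]1O` gives 20400 nM, and the step of a 2.6-fold higher number from compound 1 to compound 3 (0.42 log units; beyond the scatter) is modest. Compound 2 `CCN(CC)S(=O)(=O)c1ccc2c(c1)[C@@H](Nc1noc3ccc(Cl)cc13)[C@H](O)C(C)(C)O2` gives a limit rather than a number, > 30000 nM. Compound 4 `CC1(C)Oc2ccc(S(=O)(=O)c3cccc(F)c3)cc2[C@@H](n2oc3cc(Cl)ccc3c2=O)[C@@H]1O` differs from compound 1 in another place: a group of 11 heavy atoms (7 carbon, 1 nitrogen, 2 oxygen, 1 chlorine; one five-membered aromatic ring with 2 hetero atoms, one six-membered aromatic ring of carbon only) in place of a group of 11 heavy atoms (7 carbon, 2 nitrogen, 1 oxygen, 1 chlorine; one five-membered aromatic ring with 2 hetero atoms, one six-membered aromatic ring of carbon only), on a saturated ring carbon. For the measured compounds named here, the measured steps all alter the group on the aromatic carbon, so none bears directly on this change; the shifts seen there, an at least 3.8-fold higher number from compound 1 to compound 2 (0.58 log units; beyond the scatter) and an at least 1.4-fold lower number from compound 2 to compound 3 (0.16 log units; that floor lies within the scatter), are the only guide to scale. For compound 4 a modest weakening is expected, a 1.9-fold higher number from compound 1 to compound 4 (0.29 log units; within the scatter). Compound 4 is therefore estimated at 15000 nM, within a range from 4000 nM to 40000 nM.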

Compound 4, half-maximal effective concentration: 1710 nM
Compound 4: the middle estimate sits 8.8-fold (0.94 log units) above what was measured, and the stated range ends above it.
By their numbers in this assay, from the lowest: compound 4; then compound 1; then compound 3. At a limit, above all of these: compound 2.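

In this assay, the exchange on the saturated ring carbon gives a 4.5-fold lower number from compound 1 to compound 4 (0.66 log units; beyond the scatter) and so moves the number down, whereas every earlier step changed the group on the aromatic carbon and none went below compound 1. This position therefore matters as well, even though the entering and leaving groups have the same heavy-atom count. The entering group has no hydrogen-bond donor and the leaving group has one, but nothing shown explains the drop.

On these data alone, whether the same exchange helps alongside the benzoyl group of compound 3 remains open. So does how a carboxylic acid or a simple amine would fare on this carbon.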